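Two aromatic swaps in a small cytotoxicity series

This account rests on a few compounds, and the source may have more. Where it says the series, first, only, none or still open, it means among the compounds named here.

Measured compounds:
Compound 1, `O=C(/C=C/c1ccco1)c1ccc(NC(=O)c2cccs2)cc1`: 50000 nM
Compound 2, `O=C(/C=C/c1ccco1)c1ccc(NC(=O)c2ccccc2)cc1`: 76000 nM
Compound 3, `O=C(/C=C/c1ccccc1)c1ccc(NC(=O)c2cccs2)cc1`: 28000 nM

All three were tested in a functional assay on HT-29 cells (Homo sapiens) for cytotoxicity, read by resazurin assay, with a stated time of 48 h; a lower number here means that less compound is needed, a higher number that more compound is needed for the effect. Compound 1 and compound 2 differ in one place: phenyl in place of thiophen-2-yl on a carbonyl carbon That change produced a 1.5-fold higher number from compound 1 to compound 2 (0.18 log units; within the scatter). Compound 3 carries a different core than compound 1: phenyl in place of furan-2-yl on a double-bonded chain carbon bound to a double-bonded chain carbon This second change gave a 1.8-fold lower number from compound 1 to compound 3 (0.25 log units; within the scatter).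

Compound 4, `O=C(/C=C/c1ccccc1)c1ccc(NC(=O)c2ccccc2)cc1`, has not yet been measured. It differs from compound 3 by the same change seen between compound 1 and compound 2: phenyl in place of thiophen-2-yl on a carbonyl carbon The place is described identically, so this is the same change. This swap has already been seen once, and because a 1.5-fold higher number from compound 1 to compound 2 (0.18 log units; within the scatter) stayed within the scatter, it is not expected to move the number much here either. On that basis the step from compound 3 to compound 4 is expected to be small, namely an expected 1.4-fold higher number from compound 3 to compound 4 (0.15 log units; within the scatter). Compound 4 is therefore estimated at 40000 nM, expected to fall between 20000 nM and 80000 nM.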

Compound 4, half-maximal effective concentration: 36000 nM
Estimate against measurement, compound 4: 1.1-fold (0.05 log units) above; the range from low to high includes it.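

Putting phenyl in place of thiophen-2-yl on the carbonyl carbon gave a 1.3-fold higher number from compound 3 to compound 4 (0.11 log units; within the scatter) and matched the earlier step on the other core: the same change on two cores in this assay, a 1.5-fold higher number (0.18 log units; within the scatter) from compound 1 to compound 2 and a 1.3-fold higher number (0.11 log units; within the scatter) from compound 3 to compound 4, 1.2-fold (0.07 log units) apart, within the scatter of two such steps.
Putting phenyl in place of furan-2-yl gave a 2.1-fold lower number from compound 2 to compound 4 (0.32 log units; beyond the scatter) and also matched its earlier counterpart: the same change on two cores in this assay, a 1.8-fold lower number (0.25 log units; within the scatter) from compound 1 to compound 3 and a 2.1-fold lower number (0.32 log units; beyond the scatter) from compound 2 to compound 4, 1.2-fold (0.07 log units) apart, within the scatter of two such steps.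
Each swap therefore carried across these two cores with much the same size, but this rests on a single pair of steps per swap in one cell line and does not show that it would hold on any other core.

From the compounds shown here alone, it remains open how an amine or a carboxylic acid in place of the phenyl on the carbonyl carbon would read. Going by these compounds, it is also open whether either swap would behave the same way on a core with a longer chain.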